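From hex-1-en-1-yl to a smaller group at the limit

The source may report more compounds than this note shows. Statements on the series, on what has been measured and on what is new or still open speak of the compounds shown alone.

Values in an ADME assay on L1210/0 cells (Mus musculus) for cytotoxicity, with a stated time of 48 h; on this read-out lower numbers stand for stronger inhibition and higher numbers for weaker inhibition:
Compound 1 `O=c1[nH]c(=O)n([C@H]2C[C@H](O)[C@@H](CO)O2)cc1/C=C/I`: 63900 nM
Compound 2 `C[S+]([O-])c1cn([C@H]2C[C@H](O)[C@@H](CO)O2)c(=O)[nH]c1=O`: > 200000 nM
Compound 3 `CCCC/C=C\c1cn([C@H]2C[C@H](O)[C@@H](CO)O2)c(=O)[nH]c1=O`: > 200000 nM

Compound 3 gives only a limit, > 200000 nM, and no number. It shares that position with one other compound, as the limit of > 200000 nM in this assay, at which 2 of the 3 values shown sit, shows. Compound 4 `C=CC#Cc1cn([C@H]2C[C@H](O)[C@@H](CO)O2)c(=O)[nH]c1=O` differs from compound 3 by a group of 4 heavy atoms (4 carbon; no ring) in place of a group of 6 heavy atoms (6 carbon; no ring), on an aromatic carbon, on an aromatic carbon of a six-membered aromatic ring with 2 nitrogen. Among the measured compounds shown here, two measured steps bear on this change: an at least 3.1-fold higher number from compound 1 to compound 3 (0.49 log units; beyond the scatter) and an at least 3.1-fold higher number from compound 1 to compound 2 (0.49 log units; beyond the scatter). Both lie beyond the scatter, but neither has a readable full size. Only compound 1 gives a number, 63900 nM, so a moderate step to a lower number is expected. Compound 4 may also stay at the limit. The expected change is an at least 2.5-fold lower number from compound 3 to compound 4 (0.39 log units; beyond the scatter). Compound 4 is estimated at 80000 nM, within an expected range of 10000 nM to 200000 nM.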

Compound 4, half-maximal inhibitory concentration: > 200000 nM
Compound 4: no number, only a limit (the forecaster's own chance of this, stated with the estimate: 45%); at least 2.5-fold (0.39 log units) between middle value and limit.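

In this assay compound 4 also gives only a limit, so the steps among compound 2, compound 3 and compound 4 cannot be read. Among the compounds shown here, compound 1, with 2-iodoethenyl, remains the only compound with a number at this position, and replacing that group with the chain of compound 4 gives an at least 3.1-fold higher number from compound 1 to compound 4 (0.49 log units; beyond the scatter). The limit now covers most of the series: the limit of > 200000 nM in this assay, at which 3 of the 4 values shown sit.

Going by these compounds, whether 2-bromoethenyl or an amine at this position would give a readable number stays open. So does how far compound 2, compound 3 and compound 4 lie from one another.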